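Lengthening a Chain and Cytotoxicity in Mouse Cells

The compounds below may be only part of what the source reports. "The series", "measured", "known", "first", "only" and "open" are said of these compounds alone.

Measured in an ADME assay on J774 cells (Mus musculus) for cytotoxicity, read by MTT assay, with a stated time of 24 h, tested at 30 uM; on this read-out higher numbers stand for a weaker effect at the one concentration tested and lower numbers for a stronger effect:
compound 1, `CCCCCCCCCCCO[C@@H]1[C@@H](O)[C@H](O[C@H]2O[C@H](CN)[C@@H](O)[C@H](O)[C@H]2N)[C@@H](N)C[C@H]1N`, gives 83.4%
compound 2, `CCCCCCCCCCCO[C@@H]1[C@@H](O)[C@H](O[C@H]2O[C@H](CN)[C@@H](O)[C@H](OCCCCCCC)[C@H]2N)[C@@H](N)C[C@H]1N`, gives 38.8%

Within the data shown here, of these two numbers, compound 2 stands lowest, that is, it shows the stronger effect on the cells; the only other value, that of compound 1, lies well beyond the scatter above it. Among the measured compounds shown here, the one step measured so far, a number 44.6 percentage points lower from compound 1 to compound 2 (beyond the scatter), is large and points downward.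

Compound 3, `CCCCCCCCCCCO[C@@H]1[C@@H](N)[C@@H](O[C@H]2[C@H](O)[C@@H](OCCCCCCCCCCC)[C@H](N)C[C@@H]2N)O[C@H](CN)[C@H]1O`, has not yet been measured. It differs from compound 2 by butyl in place of hydrogen on a saturated chain carbon, seven bonds along the chain from an oxygen on a saturated carbon. This is a further lengthening of the same chain whose first appearance gave the large drop from compound 1 to compound 2, so a move in the same downward direction is plausible, though nothing shows whether it continues or levels off. The step is therefore expected to be a modest further fall, a number 13.8 percentage points lower from compound 2 to compound 3 (beyond the scatter), with a wide range. Compound 3 is estimated at 25%, between 5% and 55%.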

Compound 3, a percentage reported as activity, at one concentration (the size of the read-out at that concentration, not a potency): 14.1%
The estimate for compound 3 lay 10.9 percentage points above the measured number; the range from low to high includes it.
By their numbers in this assay, from the lowest: compound 3; then compound 2; then compound 1.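

Lengthening the heptyl chain to undecyl at this oxygen gives a number 24.7 percentage points lower from compound 2 to compound 3 (beyond the scatter) in this assay, so the fall seen on first adding a chain does not stop at heptyl. Taken as a single change, going straight to the undecyl chain gives a number 69.3 percentage points lower from compound 1 to compound 3 (beyond the scatter), and across these three compounds a longer chain at this position goes with a stronger effect on the cells, with no compound going against that order. No available evidence explains this fall.

The compounds shown leave open whether a longer chain, such as tetradecyl, would lower the number further or whether it would level off. They also leave open how a chain ending in an amine or a carboxylic acid would behave at this oxygen.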